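Cyclopentyl in place of thiophen-2-yl: a half-life estimate

The source may report more compounds than this note shows. Statements on the series, on what has been measured and on what is new or still open speak of the compounds shown alone.

Compound 1 `O=C1Nc2c(ccc(F)c2F)C1(c1ccc(O)cc1)c1ccc(F)cc1`: 0.8 h
Compound 2 `O=C1Nc2c(ccc(F)c2F)C1(c1ccc(O)cc1)c1cccs1`: 0.7 h

Both compounds were tested in an in vivo ADME assay on the whole organism for metabolic stability, with Rattus norvegicus as the target, at a dose of 2.5 mg/kg by the intravenous route; a higher number here means that the compound lasts longer, a lower number that the compound disappears faster. Compound 2, at 0.7 h, cannot be told apart from compound 1. Compound 3 `O=C1Nc2c(ccc(F)c2F)C1(c1ccc(O)cc1)C1CCCC1`, not yet measured, carries cyclopentyl in place of thiophen-2-yl on a saturated ring carbon. One measured step changes the group at this same place: a 1.1-fold lower number from compound 1 to compound 2 (0.06 log units; within the scatter). Among the measured compounds shown here, that step exchanged one aromatic group for another, so no measurement yet covers a non-aromatic ring here. With this single step as a guide, no shift beyond the scatter is expected, and the data give no direction. The expected step is no change at the digits printed from compound 2 to compound 3 (within the scatter). Compound 3 is estimated at 0.7 h, with an expected range from 0.4 h to 1.3 h.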

Compound 3, half-life: 1.1 h
Compound 3: the middle estimate sits 1.6-fold (0.20 log units) below what was measured; the range from low to high includes it.
By their numbers in this assay, from the lowest: compounds 2, 1 and 3 (each within the scatter of the next).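

Among the compounds shown here, compound 3 puts a non-aromatic ring of carbon only at this saturated ring carbon, a kind of group the earlier compounds did not cover, and in this assay cyclopentyl in place of thiophen-2-yl gives a 1.6-fold higher number from compound 2 to compound 3 (0.20 log units; within the scatter) for this change. Cyclopentyl in place of 4-fluorophenyl gives a 1.4-fold higher number from compound 1 to compound 3 (0.14 log units; within the scatter) as the second reading, so across these three compounds, an aromatic ring at this place is not needed to keep the half-life within the scatter. Nothing measured here bears on the cause of these small differences.

The compounds shown leave open whether a group of another kind on this carbon, such as an amine like piperidin-4-yl or a carboxylic acid, would move the half-life beyond the scatter. They also say nothing about changes elsewhere on the shared core, as all three differ only at this one place.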